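The source may report more compounds than this note shows. Statements on the series, on what has been measured and on what is new or still open speak of the compounds shown alone.

Compound 1 `CCCCCCNc1nc(SCc2ccc(C(F)(F)F)cc2)nc2ccccc12`: in a functional assay on HGC-27 cells (Homo sapiens) for cytotoxicity, read by MTT assay, with a stated time of 72 h (on this read-out lower numbers stand for stronger inhibition and higher numbers for weaker inhibition), compound 1 gives 23900 nM.
Compound 2 `FC(F)(F)c1ccc(CSc2nc(Nc3cccc(Cl)c3)c3ccccc3n2)cc1`: in this assay compound 2 gives 19900 nM.
Compound 3 `COc1ccc(Nc2nc(SCc3ccc(C(F)(F)F)cc3)nc3ccccc23)cc1`: in this assay compound 3 gives 23500 nM.

On the bare numbers compound 3 is the second highest of the three, but every gap is within the scatter: a 1.0-fold lower number from compound 1 to compound 3 (0.01 log units; within the scatter) and a 1.2-fold higher number from compound 2 to compound 3 (0.07 log units; within the scatter), so the three compounds cannot be told apart on this read-out.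

Compound 4 `COc1ccc(Nc2nc(SCc3ccc(C(F)(F)F)cc3)nc3ccccc23)cc1OC` is not yet measured. It differs from compound 3 by methoxy in place of hydrogen on an aromatic carbon; cut one bond further out, the change reads 4-methoxyphenyl to 3,4-dimethoxyphenyl on the amino group of the shared core.

Among the compounds with values here, no measured step adds a methoxy to a ring already carrying one. Within the data shown here, the steps that bear on it only exchange the whole group on that nitrogen: a 1.2-fold lower number from compound 1 to compound 2 (0.08 log units; within the scatter), a 1.0-fold lower number from compound 1 to compound 3 (0.01 log units; within the scatter) and a 1.2-fold higher number from compound 2 to compound 3 (0.07 log units; within the scatter), all within the scatter. Hexyl, 3-chlorophenyl and 4-methoxyphenyl at this position give the same number, so a second methoxy on the same ring is expected to give no step beyond the scatter in this assay.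

For compound 4 the expected step is a 1.1-fold lower number from compound 3 to compound 4 (0.03 log units; within the scatter). Compound 4 is therefore estimated at 22000 nM, with a range from 10000 nM to 48000 nM.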

Compound 4, half-maximal inhibitory concentration: 17900 nM
Estimate against measurement, compound 4: 1.2-fold (0.09 log units) above, within the range that was stated.
By their numbers in this assay, from the lowest: compounds 4, 2, 3 and 1 (each within the scatter of the next).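

Within the data shown here, a second methoxy, placed ortho to a methoxy group and meta to a large group, gives a 1.3-fold lower number from compound 3 to compound 4 (0.12 log units; within the scatter) in this assay; this is the first step that adds a group to a ring already on that nitrogen instead of exchanging the whole group, and it too stays within the scatter. The exchanges leading to the new group read the same way, with a 1.1-fold lower number from compound 2 to compound 4 (0.05 log units; within the scatter) and a 1.3-fold lower number from compound 1 to compound 4 (0.13 log units; within the scatter), so hexyl, 3-chlorophenyl, 4-methoxyphenyl and 3,4-dimethoxyphenyl on this nitrogen cannot be told apart on this read-out. No measurement at hand accounts for this flat picture.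

Going by these compounds, whether a group of another kind on that nitrogen, such as a chain ending in an amine or a carboxylic acid, would give a step beyond the scatter remains open. On these data alone, the trifluoromethyl-bearing benzyl group on the sulfur is the same in all four compounds, so the effect of replacing it with, for example, a longer alkyl chain is also open.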